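Methoxy to isopropoxy in a short series

The source may report more compounds than this note shows. Statements on the series, on what has been measured and on what is new or still open speak of the compounds shown alone.

Compound 1 `O=C(/C=C/c1csc2ccccc12)c1ccccc1O` gives 6200 nM
Compound 2 `COc1ccc(O)c(C(=O)/C=C/c2csc3ccccc23)c1` gives 640 nM

In a functional assay on KB cells (Homo sapiens) for antiproliferative activity, read by sulforhodamine B assay, with a stated time of 72 h (on this read-out higher numbers stand for weaker inhibition and lower numbers for stronger inhibition), compound 2, at 640 nM here, stands lowest of the two measured. Compound 3 (`CC(C)Oc1ccc(O)c(C(=O)/C=C/c2csc3ccccc23)c1`) has isopropyl in place of methyl on an oxygen on an aromatic ring. Among the compounds with values here, one measured step bears on this, a modest one beyond the scatter (a 9.7-fold lower number from compound 1 to compound 2 (0.99 log units; beyond the scatter)), where methoxy replaced hydrogen on an aromatic carbon. It shows nothing about a larger group on that oxygen, so no change beyond the scatter is expected, with a slight lean towards a higher number. The expected step (a 1.3-fold higher number from compound 2 to compound 3 (0.10 log units; within the scatter)) is small. For compound 3 the estimated value is 800 nM with an expected range from 250 nM to 2500 nM on this read-out.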

Compound 3, half-maximal inhibitory concentration: 10000 nM
Compound 3: middle estimate off by 13-fold (1.10 log units), on the low side, and the stated range ends below it.
By their numbers in this assay, from the lowest: compound 2; then compounds 1 and 3 (each within the scatter of the next).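

In this assay the gain seen with methoxy does not extend to a larger group on this oxygen: isopropyl in place of methyl gives (a 16-fold higher number from compound 2 to compound 3 (1.19 log units; beyond the scatter)). Measured against hydrogen on the same aromatic carbon, isopropoxy shows no change beyond the scatter (a 1.6-fold higher number from compound 1 to compound 3 (0.21 log units; within the scatter)). Nothing available accounts for the loss on going from methoxy to isopropoxy.

Still open, as far as these compounds go, is where between methoxy and isopropoxy the number rises, which ethoxy would help to place. Also open, from the compounds shown here alone, is how an amine at this position would compare with methoxy.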